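Adding a nitro group to a weak cytotoxic benzothiazole amide

The compounds below may be only part of what the source reports. "The series", "measured", "known", "first", "only" and "open" are said of these compounds alone.

Measured compounds:
Compound 1, `O=C(CSc1nc2ccc(NC(=O)c3ccc([N+](=O)[O-])cc3)cc2s1)NCc1ccccc1`, > 100000 nM
Compound 2, `COc1ccc(CNC(=O)CSc2nc3ccc(NC(=O)c4ccccc4OC)cc3s2)cc1`, 9300 nM
Compound 3, `COc1ccc(CNC(=O)CSc2nc3ccc(NC(=O)c4ccccc4)cc3s2)cc1`, 21200 nM

Of the compounds shown here, three sharing one core have been tested in a functional assay on MCF7 cells (Homo sapiens) for cytotoxicity, read by MTT assay, with a stated time of 48 h; a higher number here means a weaker inhibitor, a lower number a stronger inhibitor. Compound 1, `O=C(CSc1nc2ccc(NC(=O)c3ccc([N+](=O)[O-])cc3)cc2s1)NCc1ccccc1`, gives only a limit of the assay, > 100000 nM. Compound 2, `COc1ccc(CNC(=O)CSc2nc3ccc(NC(=O)c4ccccc4OC)cc3s2)cc1`, gives 9300 nM, and compound 3, `COc1ccc(CNC(=O)CSc2nc3ccc(NC(=O)c4ccccc4)cc3s2)cc1`, gives 21200 nM, the highest of the two numbers obtained. Going by the values given here, the one step between measured compounds is a 2.3-fold higher number from compound 2 to compound 3 (0.36 log units; beyond the scatter).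

The next compound, compound 4, is `COc1ccc(CNC(=O)CSc2nc3ccc(NC(=O)c4ccc([N+](=O)[O-])cc4)cc3s2)cc1`. It differs from compound 3 in one place: nitro in place of hydrogen on an aromatic carbon.

Among the compounds with values here, no measured step concerns this change; the step from compound 2 to compound 3 alters a different part of the molecule. Within the data shown here, the only guide is compound 1, which carries the same nitro group on a different benzyl amide and in this assay sits at a limit, (the limit of > 100000 nM in this assay, at which 1 of the 3 values shown sits). On that basis compound 4 is expected to be a weak inhibitor, possibly beyond the reach of the assay, with a 2.1-fold higher number from compound 3 to compound 4 (0.33 log units; beyond the scatter). The estimate for compound 4 in this assay is 45000 nM, expected to lie between 15000 nM and 150000 nM.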

Compound 4, half-maximal inhibitory concentration: > 100000 nM
Compound 4 gave a limit, no number; the forecaster's own chance of this, stated with the estimate: 40%; at least 2.2-fold (0.34 log units) between middle value and limit.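

In this assay, the change from phenyl to 4-nitrophenyl, with the nitro group para to a large group, can now be read directly: it gives an at least 4.7-fold higher number from compound 3 to compound 4 (0.67 log units; beyond the scatter), so this change weakens the compound, and the step marks only the smallest size it can have. Replacing the 2-methoxyphenyl group with 4-nitrophenyl on the same carbonyl carbon gives an at least 10-fold higher number from compound 2 to compound 4 (1.03 log units; beyond the scatter), a large loss that combines a change of group with a change of where that group sits on the ring. Compound 1 and compound 4 differ by a methoxy group on an aromatic carbon, but that step cannot be read, and both compounds carrying the nitro group now give only a limit: the limit of > 100000 nM in this assay, at which 2 of the 4 values shown sit.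

Going by these compounds, how far the true value of compound 4 lies past its limit remains open, so the full size of the nitro step is unknown. Going by these compounds alone, also open is whether an amine or a nitrile at this same place on the ring would give a measurable number, and whether that number would differ from the one for compound 3 by more than the usual scatter.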